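Efficacy Notes: Chain Extension on the Shared Core

This account rests on a few compounds, and the source may have more. Where it says the series, first, only, none or still open, it means among the compounds named here.

Measured so far in an in vitro functional assay on 1321-N1 cells for agonist activity at Free fatty acid receptor 1 (Homo sapiens), read by fluorescence, spectrophotometry and calcium flux; a lower number here means a smaller maximal response, a higher number a larger maximal response:
compound 1 `Cc1c(C#Cc2ccc(CCC(=O)O)cc2)ccnc1Cl`: 101%
compound 2 `Cc1c(C#Cc2ccc(CCC(=O)O)cc2)cc(Cl)nc1Cl`: 91%
compound 3 `Cc1c(C#Cc2ccc(CCC(=O)O)cc2)ccnc1F`: 101%

Compound 1 stands level with compound 3 at the digits shown, the two together at the top of the three numbers; the step of no change at the digits printed from compound 1 to compound 3 (within the scatter) and the step of a number 10 percentage points lower from compound 1 to compound 2 (within the scatter) both lie within the scatter. Compound 4 `C=CCc1c(C#Cc2ccc(CCC(=O)O)cc2)ccnc1Cl` differs from compound 1 by vinyl in place of hydrogen on a saturated chain carbon bound to an aromatic carbon. Within the data shown here, neither measured step touches this site: both alter substituents on aromatic carbons, and both stayed within the scatter, so no direct precedent exists for the change. The expectation is therefore a step of a number 4 percentage points lower from compound 1 to compound 4 (within the scatter), nothing beyond the scatter. Compound 4 is estimated at 97%, expected to fall between 85% and 106% in this assay.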

Compound 4, largest response reached (reported as efficacy), in percent of the reference or control that the assay uses: 97%
For compound 4 middle estimate and measured number coincide at the digits printed; the range from low to high includes it.
By their numbers in this assay, from the lowest: compounds 2, 4, 1 and 3 (each within the scatter of the next).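

In this assay, among these compounds, the saturated chain carbon bound to an aromatic carbon, a site the earlier steps leave untouched, takes vinyl in place of hydrogen with a number 4 percentage points lower from compound 1 to compound 4 (within the scatter). Methyl to allyl is thus a change at this site that keeps the maximal response within the scatter, extending the tolerated changes from aromatic carbons to this chain. Nothing on hand explains this result.

From the compounds shown here alone, whether a longer saturated chain such as butyl, or an amine or a carboxylic acid at the end of the chain, would keep this response remains open. Among the compounds shown here, the single allyl example also leaves open how far the chain can extend.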